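The source may hold more compounds than are shown below. What is called first, only, known or untested is meant among the compounds shown, and "the series" means these compounds.

Compound 1 `COC(=O)C1=C(C)N(c2ccc(Br)cc2)C(C)=C(C(=O)OC)C1[C@@H]1O[C@H]2OC(C)(C)O[C@H]2[C@@H]1OC`: 48.5 ug/mL
Compound 2 `CCOC(=O)C1=C(C)N(c2ccc(C)cc2)C(C)=C(C(=O)OCC)C1[C@@H]1O[C@H]2OC(C)(C)O[C@H]2[C@@H]1OC`: "not determined" (no result reported)

Going by the values given here, in an ADME assay on J774.A1 cells (Mus musculus) for cytotoxicity, read by MTT assay, with a stated time of 72 h (on this read-out higher numbers stand for lower toxicity in this test and lower numbers for higher toxicity in this test), compound 1 gives 48.5 ug/mL, the only number available in this small set. Compound 2 has no place on that scale, since its entry reads "not determined" (no result reported) and no result was reported for it. The next compound, compound 3 `CCOC(=O)C1=C(C)N(c2ccccc2OC)C(C)=C(C(=O)OCC)C1[C@@H]1O[C@H]2OC(C)(C)O[C@H]2[C@@H]1OC`, is related to compound 2 by a single change, 2-methoxyphenyl in place of 4-methylphenyl on an amine nitrogen in a ring. Among the compounds with values here, no measured pair shows what a change at this place does in this assay, so neither a direction nor a step beyond the usual scatter is expected. Within the data shown here, the only anchor is compound 1 at 48.5 ug/mL, and the expectation stays close to it. For compound 3 the estimated value is 50 ug/mL, with an expected range of 20 ug/mL to 120 ug/mL.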

Compound 3, half-maximal cytotoxic concentration: 49.7 ug/mL
For compound 3 the middle estimate is 1.0-fold (0.00 log units) above the measured one; low and high end bracket the measured number.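

Going by these compounds alone, compound 2 carries no number in this assay, so no step from it to compound 3 can be read. The compounds shown leave open what 2-methoxyphenyl in place of 4-methylphenyl does in this assay, and no other evidence here bears on the result.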